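Chloro for Fluoro on the Benzyl Arm of a Dithiocarbamate

The compounds below may be only part of what the source reports. "The series", "measured", "known", "first", "only" and "open" are said of these compounds alone.

This account concerns bis-benzylidene piperidinone dithiocarbamates that share a core: compound 1, compound 2 and compound 3. Compound 1 `O=C1/C(=C/c2ccccc2F)CN(C(=S)SCc2cn(Cc3cccc(Cl)c3)nn2)C/C1=C\c1ccccc1F` has been tested in a functional assay on PC-3 cells (Homo sapiens) for cytotoxicity, read by MTT assay, with a stated time of 24 h (a higher number here means a weaker inhibitor, a lower number a stronger inhibitor), where compound 1 gives 80000 nM. Compound 2 `Cc1ccc(/C=C2\CN(C(=S)SCc3cn(Cc4ccccc4F)nn3)C/C(=C\c3ccc(C)cc3)C2=O)cc1` was read in this assay only as a limit of the assay, at > 80000 nM. On the numbers shown, compound 2 therefore stands at the limit, where one of the two values sits (the limit of > 80000 nM in this assay, at which 1 of the 2 values shown sits), and no number can be given for it. Compound 3 `Cc1ccc(/C=C2\CN(C(=S)SCc3cn(Cc4ccccc4Cl)nn3)C/C(=C\c3ccc(C)cc3)C2=O)cc1` differs from compound 2 in one place: chloro in place of fluoro on an aromatic carbon. Within the data shown here, no measured pair in this set isolates this change, so any expectation rests on compound 2 alone. The step expected from compound 2 to compound 3 is a number no higher from compound 2 to compound 3 (the limit leaves the size open), which the writer takes to lie within the scatter rather than beyond it in either direction. Compound 3 is accordingly expected to give about 80000 nM in this assay, with a range from 40000 nM to 160000 nM, and there is a real chance that only a limit is reported.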

Compound 3, half-maximal inhibitory concentration: > 80000 nM
Compound 3 ended at the assay's limit; the forecaster's own chance of this, stated with the estimate: 55%; the middle value sits exactly at the limit.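

Among these compounds, compound 2 and compound 3 both stand at a limit of this assay and not at a number, so no step between them can be read. The compounds shown leave open whether going from 2-fluorobenzyl to 2-chlorobenzyl changes the reading at all.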